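The source may hold more compounds than are shown below. What is called first, only, known or untested is meant among the compounds shown, and "the series" means these compounds.

Measured compounds:
compound 1 `Cc1nc(N)nc2c1c(-c1ccc3oc(N)nc3c1)nn2C(C)C`, in an ADME assay on cells (Hepatocyte, Homo sapiens) for metabolic stability, read by LC-MS, with a stated time of 90 min, tested at 1 uM (a higher number here means faster removal of the compound, a lower number slower removal), compound 1 gives < 5 uL/min.
compound 2 `CC(C)n1nc(-c2ccc3oc(N)nc3c2)c2c(F)nc(N)nc21`, compound 2 gives 57 uL/min.
compound 3 `CC(C)n1nc(-c2ccc3oc(N)nc3c2)c2c(=O)[nH]c(N)nc21`, compound 3 gives < 5 uL/min.

The value of compound 1 is a limit of the assay, not a number. The value of compound 3 is likewise a limit (the limit of < 5 uL/min in this assay, at which 2 of the 3 values shown sit). Compound 3 thus stands at the slow end of what this assay resolves, at a limit rather than a measured figure, while only compound 2 yields a number. Going by the values given here, the one step that runs between measured compounds, an at least 11-fold higher number from compound 1 to compound 2 (1.05 log units; beyond the scatter), puts fluoro in place of methyl and is large, yet it does not touch the position altered here.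

Compound 4 `Cc1nc2c(c(-c3ccc4oc(N)nc4c3)nn2C(C)C)c(=O)[nH]1` differs from compound 3 at one place: methyl in place of amino on an aromatic carbon. No measured pair shows amino giving way to methyl, so the step from compound 3 to compound 4 has no direct precedent among these compounds. Compound 1 carries a methyl on its core and also sits at a limit of the assay. With the carbonyl of compound 3 retained, the expected step is an at least 1.2-fold higher number from compound 3 to compound 4 (0.07 log units; that floor lies within the scatter), small and within scatter. Compound 4 is therefore estimated at 6 uL/min, between 3 uL/min and 15 uL/min, with a fair chance that only a limit is again reported.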

Compound 4, intrinsic clearance in a liver preparation (reported as CLH), per the amount of preparation that the assay uses: < 5 uL/min
Compound 4 was reported as a limit; the forecaster's own chance of this, stated with the estimate: 45%; middle value at least 1.2-fold (0.07 log units) away from the limit.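

In this assay compound 4 gives < 5 uL/min, a limit and not a number. Going by these compounds alone, compound 3 also stands at a limit, so no step between compound 3 and compound 4 can be read: the limit of < 5 uL/min in this assay, at which 3 of the 4 values shown sit. The compounds shown leave open whether methyl in place of amino on this aromatic carbon changes the rate of removal at all.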